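The compounds below may be only part of what the source reports. "The series", "measured", "known", "first", "only" and "open" are said of these compounds alone.

Working notes on the series. In a functional assay on the whole organism (strain albino) for inhibition, with Rattus norvegicus as the target, read by paw edema, with stated times of 30 min and 1 h, at a dose of 100 mg/kg by the oral route (a lower number here means less inhibition, a higher number more inhibition at the dose given (going by the name of the read-out)), compound 2 `COc1ccc(C2=NN(C(=O)CO[N+](=O)[O-])C(c3c(Cl)cccc3Cl)C2)cc1OC` gives 40%. Compound 1 `COc1ccc(C2=NN(C(=O)CO[N+](=O)[O-])C(c3ccco3)C2)cc1OC` gives 32% in this assay, and compound 3 `COc1ccc(C2=NN(C(=O)CO[N+](=O)[O-])C(c3c(Cl)cccc3Cl)C2)cc1` gives 34%. Compound 2 thus holds the highest of the three numbers, but both other compounds lie within the scatter of it: a number 8 percentage points higher from compound 1 to compound 2 (within the scatter), and a number 6 percentage points lower from compound 2 to compound 3 (within the scatter). Compound 4 `COc1ccc(C2=NN(C(=O)C(C)Br)C(c3c(Cl)cccc3Cl)C2)cc1OC` is not yet measured. It differs from compound 2 in one place: 1-bromoethyl in place of (nitrooxy)methyl on a carbonyl carbon. For the measured compounds named here, neither measured step touches the carbonyl carbon, one exchanging the group on the saturated ring carbon, the other a methoxy on an aromatic carbon, so no measured step bears directly on this change. A step beyond the scatter is therefore not expected, and the expected step is a number 4 percentage points lower from compound 2 to compound 4 (within the scatter). For compound 4 the estimate in this assay is 36%, with a range of 20% to 52%.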

Compound 4, a percentage reported as inhibition, in the whole organism at one dose (the size of the read-out at that dose, not a potency): 51%
For compound 4 the middle estimate is 15 percentage points below the measured one; the range from low to high includes it.
By their numbers in this assay, from the lowest: compounds 1, 3 and 2 (each within the scatter of the next); then compound 4.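

In this assay, for the compounds shown here, the carbonyl carbon gives the first single exchange that lies beyond the scatter, with a number 11 percentage points higher from compound 2 to compound 4 (beyond the scatter) on going from (nitrooxy)methyl to 1-bromoethyl. The (nitrooxy)methyl group is therefore not required for inhibition at this dose, and this position responds where the exchanges on the saturated ring carbon and the aromatic carbon stayed within the scatter. Nothing shown accounts for this step.

Open, as far as these compounds go, is whether the step belongs to the bromine or to the carbon chain, which a plain ethyl group on the same carbonyl carbon would separate. Also open, from the compounds shown here alone, is how an amine such as aminomethyl would read at this position.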